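Adding an ethoxy group to compound 2

This account rests on a few compounds, and the source may have more. Where it says the series, first, only, none or still open, it means among the compounds named here.

Compound 1 `C#CCOc1ccc(-c2cc(-c3ccc(OCC#C)cc3)nc(C)n2)cc1` and compound 2 `C#CCOc1ccc(-c2cc(-c3ccc(OCC#C)cc3)nc(-c3ccccc3)n2)cc1` share the same core and differ only in the group on one aromatic carbon. In an assay on BTI-TN-5B1-4 cells for inhibition of Amine oxidase [flavin-containing] A (Homo sapiens), read by fluorescence and Amplex Red, using microsomes, with a stated time of 30 min (a lower number here means a stronger inhibitor, a higher number a weaker inhibitor), compound 1 gives 34200 nM and compound 2 gives 25600 nM; the step between them is a 1.3-fold lower number from compound 1 to compound 2 (0.13 log units; within the scatter). On the numbers shown, compound 2 sits at one end, with compound 1 as its nearest neighbour and within the scatter of it. Compound 3 `C#CCOc1ccc(-c2cc(-c3ccc(OCC#C)c(OCC)c3)nc(-c3ccccc3)n2)cc1` carries ethoxy in place of hydrogen on an aromatic carbon. Going by the values given here, no measured step touches this position; the only step available changes a different group and was itself within the scatter, so it gives no direction for an added ethoxy group. The expectation is therefore no step beyond the scatter, the estimated step being a 1.2-fold lower number from compound 2 to compound 3 (0.07 log units; within the scatter). Compound 3 is expected to give 22000 nM in this assay, with a range from 8000 nM to 60000 nM.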

Compound 3, half-maximal inhibitory concentration: "not active" (no number reported)
The entry for compound 3 holds no number; the estimate stays without a comparison.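

In this assay, going by these compounds alone, compound 3 is recorded as "not active" without a number, and no step from compound 2 to compound 3 can be read. No available evidence bears on this result. The compounds shown leave open whether the added ethoxy group shifts the value of compound 2 at all, and by how much.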